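A few compounds are considered here, and "the series" means these few. Any claim that something is new, unique, unknown or untested is made for them only; others in the source may bear on it.

In a functional assay on HepG2 cells (Homo sapiens) for inhibition, read by WST assay, with stated times of 72 h and 2 h (on this read-out lower numbers stand for stronger inhibition and higher numbers for weaker inhibition), compound 1 `OC(c1cccs1)c1cc2ccccc2nc1Cl`, with a hydrogen on the oxygen, gives 80800 nM. Placing propargyl on that oxygen gives compound 2 `C#CCOC(c1cccs1)c1cc2ccccc2nc1Cl`. Compound 2 reads > 100000 nM, which is a limit of the assay and not a number. Compound 2 is the only such case here, as the limit of > 100000 nM in this assay, at which 1 of the 3 values shown sits, shows. Compound 3 `Oc1ccc(-c2cc(COC(c3cccs3)c3cc4ccccc4nc3Cl)on2)cc1`, with a larger group on the same oxygen, gives 179000 nM, so numbers in this high range can still be read.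

Compound 4 `Fc1ccc(COC(c2cccs2)c2cc3ccccc3nc2Cl)cc1` has not yet been measured. It differs from compound 2 as follows: 4-fluorophenyl in place of ethynyl on a saturated chain carbon bound to an oxygen on a saturated carbon. In words, 4-fluorophenyl stands in place of ethynyl on a saturated chain carbon bound to an oxygen on a saturated carbon, so propargyl becomes 4-fluorobenzyl.

Among the measured compounds shown here, the one measured step at this oxygen is an at least 1.2-fold higher number from compound 1 to compound 2 (0.09 log units; that floor lies within the scatter). That figure is only a floor, so it does not fix the true size of the step. Compound 1 and compound 3 both carry real numbers in the same high range, so a large move in this assay is not expected, in either direction. The estimated step is an at least 1.1-fold lower number from compound 2 to compound 4 (0.04 log units; that floor lies within the scatter), which means no change beyond the scatter is expected. For compound 4 the estimated value is 90000 nM, with an expected range from 35000 nM to 200000 nM.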

Compound 4, half-maximal inhibitory concentration: "not active" (no number reported)
The entry for compound 4 holds no number, and the estimate cannot be compared.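

Among the compounds shown here, compound 4 is reported in this assay as "not active", with no number, so no step from compound 2 to compound 4 can be read. Compound 2 carries a limit of the assay and not a number: the limit of > 100000 nM in this assay, at which 1 of the 4 values shown sits. The compounds shown leave open whether 4-fluorobenzyl and propargyl on this oxygen differ at all.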